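A few compounds are considered here, and "the series" means these few. Any claim that something is new, unique, unknown or untested is made for them only; others in the source may bear on it.

Of the compounds shown here, two have numbers so far. Compound 1 `CC(C)c1onc(-c2c(Cl)cccc2Cl)c1COc1ccc(-c2nc3ccc(C(=O)O)cc3n2C(C)C)cc1` gives 3550 nM in an assay on HEK-293T cells for antagonist activity at vitamin D3 receptor (Homo sapiens), read by a luciferase reporter, with a stated time of 24 h (on this read-out higher numbers stand for weaker inhibition and lower numbers for stronger inhibition), the higher of the two numbers shown, though its gap to compound 2 is within the scatter. Compound 2 `CC(C)c1onc(-c2c(Cl)cccc2Cl)c1COc1ccc(-c2nc3ccc(C(=O)O)cc3n2C)cc1Cl` gives 2450 nM in this assay. Compound 3 `CC(C)c1onc(-c2c(Cl)cccc2Cl)c1COc1ccc(-c2nc3ccc(C(=O)O)cc3n2C2CCCCCC2)cc1` remains to be measured and differs from compound 1 in a single place: cycloheptyl in place of isopropyl on an aromatic nitrogen. Going by the values given here, no measured pair shows what this change does, so the step of a 1.3-fold lower number from compound 1 to compound 3 (0.10 log units; within the scatter) is expected to stay small, with no clear direction beyond the scatter. Compound 3 is estimated at 2800 nM, with a range from 900 nM to 9000 nM.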

Compound 3, half-maximal inhibitory concentration: 921 nM
Compound 3: middle estimate off by 3.0-fold (0.48 log units), on the high side; low and high end bracket the measured number.
By their numbers in this assay, from the lowest: compound 3; then compounds 2 and 1 (each within the scatter of the next).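

Cycloheptyl in place of isopropyl on the aromatic nitrogen brings a 3.9-fold lower number from compound 1 to compound 3 (0.59 log units; beyond the scatter) in this assay and this modest step lies beyond the scatter. Going by these compounds alone, it is the first sign that inhibition responds to the group at this position, and that a seven-membered carbon ring is tolerated there with stronger inhibition. Nothing at hand explains the step.

Within the data shown here, whether the gain follows ring size, carbon count or the presence of a ring remains open, since only two groups are compared at this position. Cyclopentyl, cyclohexyl or a longer chain such as n-heptyl would help to separate these readings.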